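Swapping fluoro for chloro on a weakly cytotoxic compound

The source may hold more compounds than are shown below. What is called first, only, known or untested is meant among the compounds shown, and "the series" means these compounds.

- compound 1 `O=S(=O)(NCCCNc1nccc(-c2[nH]c(-c3ccccc3)nc2-c2ccc(F)c(O)c2)n1)c1ccccc1`: 9580 nM
- compound 2 `COc1ccc(S(=O)(=O)NCCCNc2nccc(-c3[nH]c(-c4ccccc4)nc3-c3ccc(F)c(O)c3)n2)cc1`: 13900 nM

Both values come from a functional assay on LOX IMVI cells (Homo sapiens) for cytotoxicity, read by MTT assay, with a stated time of 24 h; on this read-out higher numbers stand for weaker inhibition and lower numbers for stronger inhibition. Only these two compounds have been measured, and they lie within the scatter of each other, so neither can be ranked ahead of the other. Among the measured compounds shown here, compound 2 therefore stands level with compound 1, its only measured neighbour.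

The next compound is compound 3 `COc1ccc(S(=O)(=O)NCCCNc2nccc(-c3[nH]c(-c4ccccc4)nc3-c3ccc(Cl)c(O)c3)n2)cc1`, which differs from compound 2 at a single spot: chloro in place of fluoro on an aromatic carbon. In words, this is chloro in place of fluoro on an aromatic carbon, turning 4-fluoro-3-hydroxyphenyl into 4-chloro-3-hydroxyphenyl. For the measured compounds named here, no measured pair shows this swap, so the data give no direct guide to its size. Going by the values given here, the one measured step, a 1.5-fold higher number from compound 1 to compound 2 (0.16 log units; within the scatter), is methoxy in place of hydrogen, a different change, and it bears on this one only loosely. Since that step stayed within the scatter, no change beyond the scatter is expected in this assay, in either direction. The expected step is a 1.2-fold lower number from compound 2 to compound 3 (0.06 log units; within the scatter). For compound 3 the estimated value is 12000 nM, with an expected range of 5500 nM to 26000 nM.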

Compound 3, half-maximal inhibitory concentration: 36800 nM
Estimate against measurement, compound 3: 3.1-fold (0.49 log units) below; measured number outside the range, above it.
By their numbers in this assay, from the lowest: compounds 1 and 2 (each within the scatter of the next); then compound 3.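

In this assay, among the compounds shown here, the swap of chloro for fluoro, on an aromatic carbon ortho to a hydroxy group and para to a large group, gives a 2.6-fold higher number from compound 2 to compound 3 (0.42 log units; beyond the scatter) and is the first step in this small set to pass beyond the scatter. This shows that the position is not indifferent: one heavy atom is exchanged for one heavy atom, with no change in the counted hydrogen-bond donors, hydrogen-bond acceptors, rings or net charge, and yet the number moves modestly towards weaker inhibition. No available measurement accounts for this step.

With a single swap at this carbon, the compounds shown cannot reveal a trend, so it remains open whether a bromo, methyl or amino group there would give a higher or lower number than fluoro or chloro. From the compounds shown here alone, it is also open whether the same swap would produce a similar step on compound 1, which carries hydrogen where compound 2 carries methoxy, or on a compound with a longer chain in place of the present one.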